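Cytotoxicity notes: amide-nitrogen variation and the outlook for compound 4

A few compounds are considered here, and "the series" means these few. Any claim that something is new, unique, unknown or untested is made for them only; others in the source may bear on it.

Measured so far in an ADME assay on MT4 cells (Homo sapiens) for cytotoxicity, with a stated time of 5 days; on this read-out lower numbers stand for higher toxicity in this test and higher numbers for lower toxicity in this test:
Compound 1 `CON=C1CCC(N(c2cc(C#CC(C)(C)C)sc2C(=O)O)C(=O)[C@H]2CC[C@H](C)CC2)CC1` sits at a limit of this assay, > 20000 nM.
Compound 2 `CC(C)N(c1cc(C#CC(C)(C)C)sc1C(=O)O)C(=O)[C@H]1CC[C@H](C)CC1` sits at a limit of this assay, > 20000 nM.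
Compound 3 `CC(C)(C)C#Cc1cc(N(C(=O)[C@H]2CC[C@H](C)CC2)[C@H]2CC[C@H](O)CC2)c(C(=O)O)s1` sits at a limit of this assay, > 20000 nM.

Compound 3 therefore stands level with the other two on the numbers shown, since (the limit of > 20000 nM in this assay, at which 3 of the 3 values shown sit); no order among them is readable. The steps a step that the two limits leave unreadable from compound 1 to compound 2, a step that the two limits leave unreadable from compound 1 to compound 3 and a step that the two limits leave unreadable from compound 2 to compound 3 all change the group on the amide-type nitrogen, and each is unreadable in size.

Compound 4 `CC(C)(C)C#Cc1cc(N(C(=O)[C@H]2CC[C@H](C)CC2)[C@H]2CC[C@H](Oc3cccnc3)CC2)c(C(=O)O)s1` differs from compound 3 by pyridin-3-yl in place of hydrogen on an oxygen on a saturated carbon. The step bearing on it most directly, a step that the two limits leave unreadable from compound 2 to compound 3, is unreadable, as are the others, so no shift beyond the scatter can be expected from the steps shown. Compound 4 is expected to remain at the limit, with an estimate of 30000 nM (range 8000 nM to 100000 nM). The expected step is a step that the limit leaves unreadable from compound 3 to compound 4.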

Compound 4, half-maximal cytotoxic concentration: > 20000 nM
Compound 4: only a limit was reported; the forecaster's own chance of this, stated with the estimate: 80%; the middle value is on the limit's open side.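

No step can be read from compound 3 to compound 4, since both sit at one limit: the limit of > 20000 nM in this assay, at which 4 of the 4 values shown sit.

The compounds shown leave open whether any of the four differ at all in this assay.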